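Adding a Dimethylamino Group to a Long-Lived Anilide

A few compounds are considered here, and "the series" means these few. Any claim that something is new, unique, unknown or untested is made for them only; others in the source may bear on it.

Compound 1 `C/C=C/C(=O)Nc1ccccc1`: > 8.53 h
Compound 2 `C=C(CCO)C(=O)Nc1ccccc1`: > 8.53 h
Compound 3 `C=C(CN(C)C)C(=O)Nc1ccccc1`: < 0.0334 h

In an ADME assay for pharmacokinetics, read by LC-MS, in phosphate buffer, with a stated time of 120 min, at pH 7.4, tested at 1 uM, in the presence of a further agent that is not named here (on this read-out higher numbers stand for a longer-lived compound and lower numbers for a shorter-lived compound), compound 1 gives > 8.53 h, which is a limit of the assay rather than a number. Compound 2 sits at the same limit, (the limit of > 8.53 h in this assay, at which 2 of the 3 values shown sit). Compound 3 sits at the opposite limit, (the limit of < 0.0334 h in this assay, at which 1 of the 3 values shown sits).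

Compound 4 `CN(C)C/C=C/C(=O)Nc1ccccc1` differs from compound 1 by dimethylamino in place of hydrogen on a saturated chain carbon bound to a double-bonded chain carbon. Within the data shown here, the one measured step that bears on this change is an at least 250-fold lower number from compound 2 to compound 3 (2.40 log units; beyond the scatter), where the same dimethylamino group arrives and the value falls from the upper limit to the lower one. A step of similar direction and size is therefore expected in this assay. Compound 4 is expected to give 0.03 h, within a range of 0.005 h to 0.5 h. This corresponds to an expected step of an at least 280-fold lower number from compound 1 to compound 4 (2.45 log units; beyond the scatter), and the outcome may again be reported only as a limit.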

Compound 4, half-life: 1.93 h
Compound 4: middle estimate off by 64-fold (1.81 log units), on the low side, and the stated range ends below it.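

In this assay, dimethylamino in place of hydrogen on a saturated chain carbon bound to a double-bonded chain carbon gives an at least 4.4-fold lower number from compound 1 to compound 4 (0.64 log units; beyond the scatter). Even so, compound 4 gives a true number, 1.93 h. Compound 1 stands at a limit, so the real size of the step remains unknown: the limit of > 8.53 h in this assay, at which 2 of the 4 values shown sit.

The compounds shown do not explain why the half-life shortens. On these data alone, whether another amine, such as piperidine, or a longer chain carrying dimethylamino, would shorten it as much stays open.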